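Methanesulfonamido replacing piperidin-1-yl on the shared core

The source may hold more compounds than are shown below. What is called first, only, known or untested is meant among the compounds shown, and "the series" means these compounds.

In a functional assay on ID8 cells (Mus musculus) for antiproliferative activity (on this read-out lower numbers stand for stronger inhibition and higher numbers for weaker inhibition), compound 1 (`O=C(Nc1ccc(O)c2c(=O)cc(-c3ccccc3Cl)oc12)c1ccc(Cl)cc1`) gives 5500 nM and compound 2 (`O=c1cc(-c2ccccc2Cl)oc2c(N3CCCCC3)ccc(O)c12`) gives 5700 nM so compound 2 stands level with compound 1, within the scatter. Compound 3 (`CS(=O)(=O)Nc1ccc(O)c2c(=O)cc(-c3ccccc3Cl)oc12`) carries methanesulfonamido in place of piperidin-1-yl on an aromatic carbon, para to a hydroxy group (methanesulfonamido in place of piperidin-1-yl on an aromatic carbon). Going by the values given here, no measured step covers this change. In this assay no step beyond the scatter is expected, an expectation resting only on compound 1 at 5500 nM and compound 2 at 5700 nM as the two values at hand. The estimated step of a 1.0-fold lower number from compound 2 to compound 3 (0.02 log units; within the scatter) is accordingly small. For compound 3 the expected value is 5500 nM (estimated range 2000 nM to 15000 nM).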

Compound 3, half-maximal inhibitory concentration: 16000 nM
Compound 3: middle estimate off by 2.9-fold (0.46 log units), on the low side; measured number above the stated range.
By their numbers in this assay, from the lowest: compounds 1 and 2 (each within the scatter of the next); then compound 3.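

In this assay this position turns out not to be indifferent to the group it carries, although compound 1 and compound 2 stood level. Methanesulfonamido in place of piperidin-1-yl gives a 2.8-fold higher number from compound 2 to compound 3 (0.45 log units; beyond the scatter) as a modest loss, and methylsulfonyl in place of (4-chlorophenyl)carbonyl on the nitrogen gives a 2.9-fold higher number from compound 1 to compound 3 (0.46 log units; beyond the scatter) of similar size. Nothing at hand gives a reason for this shift. Open, on these data alone, is whether acetamido or a free amine on this aromatic carbon would stay level with compound 1 and compound 2 or fall nearer compound 3. As far as these compounds go, a longer alkylsulfonyl chain on the nitrogen is equally open.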